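The compounds below may be only part of what the source reports. "The series", "measured", "known", "first", "only" and "open" are said of these compounds alone.

Measured compounds:
compound 1, `Cc1ccc(OCc2cn(C(c3ccc(C#N)cc3)c3ccc(C#N)cc3)nn2)cc1`, 11000 nM
compound 2, `N#Cc1ccc(C(c2ccc(C#N)cc2)n2cc(COc3ccc(-c4ccccc4)cc3)nn2)cc1`, 13400 nM
compound 3, `Cc1ccc(OCc2cn(C(c3ccccc3)c3ccccc3)nn2)cc1`, 26800 nM

In an assay on isolated protein for inhibition of Aromatase (Homo sapiens), read by fluorescence and colorimetric assay, with a stated time of 30 min (a lower number here means a stronger inhibitor, a higher number a weaker inhibitor), compound 1 gives 11000 nM and compound 2 gives 13400 nM. The two differ in one place: phenyl in place of methyl on an aromatic carbon. This change made a 1.2-fold higher number from compound 1 to compound 2 (0.09 log units; within the scatter), so the two numbers cannot be told apart.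

Compound 3 has a different core, `Cc1ccc(OCc2cn(C(c3ccccc3)c3ccccc3)nn2)cc1`, and in this assay compound 3 gives 26800 nM. How the core of compound 3 differs from the core of compound 1 is not broken down here; the two differ in more than one place. Compound 3 shows the highest of the three numbers, and its step from compound 1 lies beyond the scatter, while its step from compound 2 lies within it.

Compound 4, `c1ccc(-c2ccc(OCc3cn(C(c4ccccc4)c4ccccc4)nn3)cc2)cc1`, has not yet been measured. It stands to compound 3 as compound 2 stands to compound 1: phenyl in place of methyl on an aromatic carbon. The place is the same in both pairs, so this is the same change on a different core.

Going by the values given here, the expectation for compound 4 rests on the one measured example of this change, because a 1.2-fold higher number from compound 1 to compound 2 (0.09 log units; within the scatter) was within the scatter. The step from compound 3 is therefore estimated to be small: a 1.2-fold higher number from compound 3 to compound 4 (0.08 log units; within the scatter). Compound 4 is expected to give about 32000 nM in this assay, with a likely range from 15000 nM to 65000 nM.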

Compound 4, half-maximal inhibitory concentration: 15500 nM
Beside the measured number, compound 4's estimate is 2.1-fold (0.31 log units) above it; the measured number falls inside the stated range.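

In this assay, going by these compounds alone, putting phenyl in place of methyl on the aromatic carbon gives a 1.7-fold lower number from compound 3 to compound 4 (0.24 log units; within the scatter), so on this core, as on the core of compound 1, the swap produces no step that can be told apart from the usual scatter of repeated measurements. Set side by side, the two steps cannot be separated from each other either: the same change on two cores in this assay, a 1.2-fold higher number (0.09 log units; within the scatter) from compound 1 to compound 2 and a 1.7-fold lower number (0.24 log units; within the scatter) from compound 3 to compound 4, 2.1-fold (0.32 log units) apart, within the scatter of two such steps. In these two pairs, then, the swap carries over from one core to the other without a detectable difference, but two pairs give no general rule for the series, and they do not show that the swap has no effect at all, only that any effect is too small for this assay to resolve.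

The compounds shown leave open whether a different group at the same place, such as an amine, a carboxylic acid or a longer chain, would move the number beyond the scatter. They also leave open how the same swap would behave on a core carrying a single nitrile, since the cores shown carry either two nitrile groups or none.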